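A few compounds are considered here, and "the series" means these few. Any claim that something is new, unique, unknown or untested is made for them only; others in the source may bear on it.

Compound 1, `Cc1ccc(C(=O)Nc2cn3ncnc3c(CN3CCN(C(=O)C4CCOCC4)[C@@H](C)C3)c2C)cn1`, is reported in an ADME assay on microsomes from liver (Homo sapiens) for metabolic stability (a lower number here means slower removal, a higher number faster removal of the compound), at < 10 mL.min-1.g-1, which is a limit of the assay and not a number (the limit of < 10 mL.min-1.g-1 in this assay, at which 1 of the 2 values shown sits). For the measured compounds named here, compound 2, `Cc1ccc(C(=O)Nc2cn3ncnc3c(CN3CCN(C(=O)C(C)C)[C@@H](C)C3)c2C)cn1`, gives 240 mL.min-1.g-1 in this assay and so carries the only full number of the pair. Going by the values given here, the single measured step is an at least 24-fold higher number from compound 1 to compound 2 (1.38 log units; beyond the scatter), a large movement. Compound 3, `Cc1ccc(C(=O)Nc2cn3ncnc3c(CN3CCN(C(=O)CC(C(F)(F)F)C(F)(F)F)[C@@H](C)C3)c2C)cn1`, has not yet been measured; it differs from compound 2 in that (3,3,3-trifluoro-2-(trifluoromethyl)propyl in place of isopropyl on a carbonyl carbon). Among the compounds with values here, the one measured step concerns a different replacement on the same carbonyl carbon, so it bears on this change only indirectly: it shows that substitution at this carbonyl carbon can move the read-out a long way, but gives no direction for the present group. Within the data shown here, with no directly comparable pair, the expected step from compound 2 is kept modest and the range wide, a 1.6-fold lower number from compound 2 to compound 3 (0.20 log units; within the scatter). Compound 3 is therefore expected to give about 150 mL.min-1.g-1 in this assay, estimated between 40 mL.min-1.g-1 and 600 mL.min-1.g-1, with a small chance that only a limit is reported.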

Compound 3, intrinsic clearance in microsomes: < 10 mL.min-1.g-1
Compound 3 ended at the assay's limit; the forecaster's own chance of this, stated with the estimate: 10%; middle value at least 15-fold (1.17 log units) from the limit.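

In this assay, the change from isopropyl to 3,3,3-trifluoro-2-(trifluoromethyl)propyl, on a carbonyl carbon whose other neighbour is an amide-type nitrogen in a ring, gives an at least 24-fold lower number from compound 2 to compound 3 (1.38 log units; beyond the scatter). This shows that a large downward step at this position is not confined to the ring-bearing oxan-4-yl group of compound 1, as an open-chain group without a ring also reaches the low end, leaving compound 2 as the only one of the three with a full number. Compound 1 and compound 3 both stand at a limit of the assay, so the step between them cannot be read, and their order stays unknown: the limit of < 10 mL.min-1.g-1 in this assay, at which 2 of the 3 values shown sit.

The compounds shown do not separate the contribution of the six fluorine atoms from that of the larger carbon chain, and an isobutyl or 3,3,3-trifluoropropyl group on the same carbonyl carbon would bear directly on that question. On these data alone, how a basic amine or a carboxylic acid at this position would behave in this assay also remains open, as does whether the values of compound 1 and compound 3 would differ on a more sensitive read-out.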